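The source may hold more compounds than are shown below. What is called first, only, known or untested is meant among the compounds shown, and "the series" means these compounds.

Measured so far:
compound 1 `COc1ccc(C2=C(c3cc(OC)c(OC)c(OC)c3)C(=O)CC2O[SiH2]C(C)(C)C)cc1OC` — > 100 ug/mL
compound 2 `COc1ccc(C2=C(c3cc(OC)c(OC)c(OC)c3)CC(O)C2=O)cc1N` — 41 ug/mL

Working notes. In an ADME assay on DU-145 cells (Homo sapiens) for cytotoxicity, read by MTT assay, with a stated time of 72 h (on this read-out higher numbers stand for weaker inhibition and lower numbers for stronger inhibition), compound 1 gives only a limit, > 100 ug/mL, so no number stands for it. Going by the values given here, compound 2 gives a number in this assay, 41 ug/mL, and sits at the other end of the two values shown; no single-change step connects it to compound 1, so the two values are only set side by side. The one observation with weight is the limit of > 100 ug/mL in this assay, at which 1 of the 2 values shown sits.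

Compound 3 `COc1ccc(C2=C(c3cc(OC)c(OC)c(OC)c3)C(=O)CC2O[SiH2]C(C)(C)C)cc1O` is the not yet measured partner of compound 1. The change is hydrogen in place of methyl on an oxygen on an aromatic ring, methoxy to hydroxy, with the rest of the core of compound 1 untouched. Among the compounds with values here, no measured step of this kind is available here, so the expected step of a number no higher from compound 1 to compound 3 (the limit leaves the size open) is set at none beyond the scatter. Compound 3 is therefore expected to give about 100 ug/mL in this assay, within 40 ug/mL to 250 ug/mL, with a real chance that again only a limit is reported.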

Compound 3, half-maximal inhibitory concentration: 75 ug/mL
The estimate for compound 3 lay 1.3-fold (0.12 log units) above the measured number, and the stated range covers the measured number.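

In this assay compound 1 gives > 100 ug/mL, and that value is a limit, not a number. With hydroxy in place of methoxy on the 3,4-dimethoxyphenyl group and the rest of the core untouched, compound 3 gives 75 ug/mL, so this single change yields a number that can be read in the series. The step is an at least 1.3-fold lower number from compound 1 to compound 3 (0.12 log units; that floor lies within the scatter), and its true size stays open because one end of it is only a limit: the limit of > 100 ug/mL in this assay, at which 1 of the 3 values shown sits.

On these data alone, whether a longer chain on that oxygen, such as ethoxy, or a carboxylic acid at this place would move the number remains open. Compound 2 differs from compound 3 in more than one place, so the compounds shown do not tell how the hydroxy group behaves on the core of compound 2.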